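A few compounds are considered here, and "the series" means these few. Any claim that something is new, unique, unknown or untested is made for them only; others in the source may bear on it.

Measured so far in a functional assay for inhibition of sodium/hydrogen exchanger (Oryctolagus cuniculus); a lower number here means a stronger inhibitor, a higher number a weaker inhibitor:
compound 1 `Cc1cc(C2CCCCC2)c(S(C)(=O)=O)cc1C(=O)N=C(N)N`: 22 nM
compound 2 `Cc1cc(N2CCCC(O)C2)c(S(C)(=O)=O)cc1C(=O)N=C(N)N`: 30 nM

Within the data shown here, compound 2 and compound 1 sit within the scatter of each other in this assay; the one step between them, a 1.4-fold higher number from compound 1 to compound 2 (0.13 log units; within the scatter), shows that exchanging the ring on this aromatic carbon left the number essentially unchanged.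

Compound 3 `Cc1cc(Nc2cccc(Cl)c2)c(S(C)(=O)=O)cc1C(=O)N=C(N)N` differs from compound 2 by (3-chlorophenyl)amino in place of 3-hydroxypiperidin-1-yl on an aromatic carbon. Among the measured compounds shown here, only the step from compound 1 to compound 2 touches the same position, and it stayed within the scatter, so no step beyond the scatter is expected here either; the change to an aromatic amine is, however, of a different kind, so the range is kept wide. Compound 3 is therefore estimated at 35 nM (range 10 nM to 120 nM), an expected step of a 1.2-fold higher number from compound 2 to compound 3 (0.07 log units; within the scatter).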

Compound 3, half-maximal inhibitory concentration: 33 nM
Estimate against measurement, compound 3: 1.1-fold (0.03 log units) above; the range from low to high includes it.
By their numbers in this assay, from the lowest: compounds 1, 2 and 3 (each within the scatter of the next).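

The aromatic carbon ortho to the methylsulfonyl group also takes (3-chlorophenyl)amino, and in this assay this group stays within the scatter of both earlier groups (a 1.1-fold higher number from compound 2 to compound 3 (0.04 log units; within the scatter); a 1.5-fold higher number from compound 1 to compound 3 (0.18 log units; within the scatter)). Across compounds 1, 2 and 3, a carbocycle, a saturated ring bound through nitrogen and an aromatic ring bound through an amine nitrogen therefore cannot be told apart at this position. No evidence bears on why these groups read alike.

Still open, from the compounds shown here alone, is whether a carboxylic acid or a longer alkyl chain on this carbon would give a step beyond the scatter. The compounds shown also leave open how plain phenylamino, without the chlorine, would read.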